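Swapping the Outer Phenyl for Pyrazolyl in Compound 4

This account rests on a few compounds, and the source may have more. Where it says the series, first, only, none or still open, it means among the compounds named here.

Of the compounds shown here, three have been measured in an assay on isolated protein for inhibition of DNA topoisomerase 1 (Homo sapiens), with a stated time of 15 min; on this read-out lower numbers stand for stronger inhibition and higher numbers for weaker inhibition. Compound 1 `CN[C@@H]1CCN(c2c(F)cc3c(=O)c(C(=O)O)cn(Cc4ccc(-c5ccccc5)cc4)c3c2OC)C1` gives 57700 nM, compound 2 `COc1c(N2CC[C@@H](CN)C2)c(F)cc2c(=O)c(C(=O)O)cn(Cc3ccc(-c4ccccc4)cc3)c12` gives 26000 nM, and compound 3 `CNC(=O)c1cn(Cc2ccc(-c3ccccc3)cc2)c2c(OC)c(N3CC[C@@H](CN)C3)c(F)cc2c1=O` gives 82100 nM. Compound 2 stands lowest of the three: a 2.2-fold lower number from compound 1 to compound 2 (0.35 log units; beyond the scatter), and a 3.2-fold higher number from compound 2 to compound 3 (0.50 log units; beyond the scatter). Both steps lie beyond the scatter, so compound 2 is the strongest inhibitor of the three on this read-out.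

Compound 4 `COc1c(N2CC[C@@H](CN)C2)c(F)cc2c(=O)c(C(=O)O)cn(Cc3ccc(-n4cccn4)cc3)c12` differs from compound 2 in one place: 1H-pyrazol-1-yl in place of phenyl on an aromatic carbon. Neither measured step touches this part of the molecule; the step from compound 1 to compound 2 alters the substituent on the saturated ring, and the step from compound 2 to compound 3 alters the substituent on the carbonyl carbon. Both were modest, and nothing measured here says whether an exchange on the outer aromatic ring moves the number at all. With no evidence pointing either way, the expected step is a 1.2-fold higher number from compound 2 to compound 4 (0.06 log units; within the scatter), none beyond the scatter, with a wide margin. Compound 4 is estimated at 30000 nM, within 10000 nM to 90000 nM.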

Compound 4, half-maximal inhibitory concentration: > 200000 nM
Compound 4: a limit, no number (the forecaster's own chance of this, stated with the estimate: 10%); middle value at least 6.6-fold (0.82 log units) from the limit.
By their numbers in this assay, from the lowest: compound 2; then compounds 1 and 3 (each within the scatter of the next). At a limit, above all of these: compound 4.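

In this assay, among these compounds, the outer aromatic ring, which no earlier step touched, proves sensitive to change: 1H-pyrazol-1-yl in place of phenyl, on an aromatic carbon para to a large group, gives an at least 7.6-fold higher number from compound 2 to compound 4 (0.88 log units; beyond the scatter). This exchange puts a five-membered aromatic ring with 2 hetero atoms where a six-membered aromatic ring of carbon only stood, and it moves the read-out further than either change at the saturated ring or the carbonyl carbon did. Compound 4 sits at a limit of the assay, not a number, so the full size of the step stays unknown: the limit of > 200000 nM in this assay, at which 1 of the 4 values shown sits.

The single exchange alters ring size and hetero atoms together, and the compounds shown do not separate the two. From the compounds shown here alone, whether a pyridyl ring, a cyclohexyl ring or an outer phenyl carrying an amine would keep the number near that of compound 2 stays open.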